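Series notes: from compound 3 to compound 4

A few compounds are considered here, and "the series" means these few. Any claim that something is new, unique, unknown or untested is made for them only; others in the source may bear on it.

Three compounds of the series have numbers in a functional assay (aorta) with Oryctolagus cuniculus as the target; a lower number here means a stronger inhibitor, a higher number a weaker inhibitor. Compound 3 `CC1=NC(C)=C(C(=O)OCCCN2C(=O)c3ccccc3S2(=O)=O)C(c2ccccc2[N+](=O)[O-])/C1=C(\O)OC(C)C` gives 1.2 nM, the lowest of the three; nearest stands compound 2 `CCO/C(O)=C1\C(C)=NC(C)=C(C(=O)OCCCN2C(=O)c3ccccc3S2(=O)=O)C1c1ccccc1[N+](=O)[O-]` with 2.6 nM, furthest compound 1 `COCCO/C(O)=C1\C(C)=NC(C)=C(C(=O)OCCCN2C(=O)c3ccccc3S2(=O)=O)C1c1cccc([N+](=O)[O-])c1` with 6.8 nM. For the measured compounds named here, the only single-point step measured so far, a 2.2-fold lower number from compound 2 to compound 3 (0.34 log units; beyond the scatter), is modest and sits at the oxygen on the unsaturated carbon.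

Compound 4 `COCCO/C(O)=C1\C(C)=NC(C)=C(C(=O)OCCCN2C(=O)c3ccccc3S2(=O)=O)C1c1ccccc1[N+](=O)[O-]` differs from compound 3 by 2-methoxyethyl in place of isopropyl on an oxygen on an unsaturated carbon. The step that bears on this place is a 2.2-fold lower number from compound 2 to compound 3 (0.34 log units; beyond the scatter), which shows that a change of the group on this oxygen moves the number by a modest amount only. Compound 1 carries the same 2-methoxyethyl group as compound 4 but differs from it elsewhere, so its number gives only a loose bound. The change from isopropyl back to a chain of comparable size is expected to undo part of the gain seen in that step, so for compound 4 a step of a 2.5-fold higher number from compound 3 to compound 4 (0.40 log units; beyond the scatter) toward a higher number is expected. Compound 4 is estimated at 3 nM, with a range from 1.2 nM to 8 nM.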

Compound 4, half-maximal inhibitory concentration: 2.7 nM
Beside the measured number, compound 4's estimate is 1.1-fold (0.05 log units) above it, and the stated range covers the measured number.
By their numbers in this assay, from the lowest: compound 3; then compounds 2 and 4 (each within the scatter of the next); then compound 1.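

In this assay the step of a 2.3-fold higher number from compound 3 to compound 4 (0.35 log units; beyond the scatter) puts 2-methoxyethyl on the oxygen on an unsaturated carbon with the group of compound 2 rather than with isopropyl, while the step of a 1.0-fold higher number from compound 2 to compound 4 (0.02 log units; within the scatter) shows that methoxy on that chain does not separate compound 4 from compound 2. Of the groups compared on this oxygen, only the isopropyl of compound 3 stands apart, as the step of a 2.2-fold lower number from compound 2 to compound 3 (0.34 log units; beyond the scatter) also shows. For the compounds shown here, the step of a 2.5-fold lower number from compound 1 to compound 4 (0.40 log units; beyond the scatter) gives the only single-place reading of the nitro group, with 2-nitrophenyl on the lower side against 3-nitrophenyl. As far as these compounds go, whether a longer chain, a terminal amine or a carboxylic acid on this oxygen would go beyond isopropyl stays open, as does whether the nitrophenyl step holds with isopropyl in place of 2-methoxyethyl. No measurement shown gives a reason for any of these steps.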